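A few compounds are considered here, and "the series" means these few. Any claim that something is new, unique, unknown or untested is made for them only; others in the source may bear on it.

Two measured compounds share one core and differ only in a halogen on an aromatic carbon. Compound 1 `CCCn1c(=O)[nH]c2nc(-c3ccc(S(=O)(=O)N4CCN(c5ccccc5Br)CC4)cc3)[nH]c2c1=O` gives 20% in an assay on CHO cells for displacement of a labelled ligand from adenosine receptor A3 (Homo sapiens), read by scintillation counting, with a stated time of 45 min, tested at 1 uM, in the presence of a further agent that is not named here; a lower number here means less inhibition, a higher number more inhibition at the concentration tested (going by the name of the read-out). Among the compounds with values here, compound 2 `CCCn1c(=O)[nH]c2nc(-c3ccc(S(=O)(=O)N4CCN(c5ccccc5F)CC4)cc3)[nH]c2c1=O` gives 9% in this assay, and it stands lowest of the two numbers, with compound 1 as its only neighbour. Within the data shown here, the single measured step, a number 11 percentage points lower from compound 1 to compound 2 (beyond the scatter), came with fluoro in place of bromo on an aromatic carbon.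

Compound 3 `CCCn1c(=O)[nH]c2nc(-c3ccc(S(=O)(=O)N4CCN(c5ccccc5Cl)CC4)cc3)[nH]c2c1=O` has not yet been measured. It differs from compound 2 by chloro in place of fluoro on an aromatic carbon. Among the measured compounds shown here, the only measured step that bears on this change is a number 11 percentage points lower from compound 1 to compound 2 (beyond the scatter): exchanging one halogen for another on that aromatic carbon moved the number by a modest amount, beyond the scatter. Chloro is the one halogen here without a measurement, and nothing measured tells how it compares with fluoro or bromo. A modest rise from compound 2 is therefore expected, smaller than the step seen from bromo to fluoro, or possibly none beyond the scatter. Compound 3 is expected to give 14% in this assay, with a range of 4% to 26%. The expected step is a number 5 percentage points higher from compound 2 to compound 3 (within the scatter).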

Compound 3, a percentage reported as inhibition, at one concentration (the size of the read-out at that concentration, not a potency): 32%
The estimate for compound 3 lay 18 percentage points below the measured number; the measured number lies above the stated range.
By their numbers in this assay, from the lowest: compound 2; then compound 1; then compound 3.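

Chloro in place of fluoro on this aromatic carbon, ortho to a large group, gave a number 23 percentage points higher from compound 2 to compound 3 (beyond the scatter) in this assay, and chloro in place of bromo gave a number 12 percentage points higher from compound 1 to compound 3 (beyond the scatter). The earlier pair alone allowed the reading that the number simply rises from fluoro to bromo, with chloro falling somewhere between them, but compound 3 goes against that reading: the three halogens do not line up in the order fluoro, chloro, bromo, and chloro carries the highest number of the three. The position is therefore sensitive to which halogen it holds, though all three results are readings at a single concentration and give no potency.

No measurement at hand explains why chloro stands apart from the other two halogens. Going by these compounds, it remains open whether a methyl, a methoxy or a trifluoromethyl group at this place would match or pass the number of compound 3, and whether a chloro on another carbon of the same ring would keep it.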